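The compounds below may be only part of what the source reports. "The series", "measured", "known", "first", "only" and "open" are said of these compounds alone.

Compound 1 `Cc1c(N(C)C)c(=O)n(C)c(=O)n1-c1ccc(Cl)cc1` and compound 2 `Cc1c(N2CCCC2)c(=O)n(-c2ccccc2)c(=O)n1C` share a core. In a physicochemical assay for lipophilicity (a lower number here means a more polar compound, a higher number a more lipophilic compound), compound 1 gives 2.32, and in this assay compound 2 gives 2.26; the gap between them falls within the scatter, so compound 2 stands together with compound 1 rather than apart from it. Compound 3 `Cc1c(N(C)C)c(=O)n(-c2ccccc2)c(=O)n1C` carries the change (dimethylamino in place of pyrrolidin-1-yl on an aromatic carbon). Among the measured compounds shown here, no pair of measured compounds covers this change, so no measured step guides it. A downward step beyond the scatter is expected, a number 0.46 log units lower from compound 2 to compound 3 (beyond the scatter). Compound 3 is estimated at 1.8 in this assay, within a range from 1.4 to 2.2.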

Compound 3, partition coefficient: 1.3
The estimate for compound 3 lay 0.50 log units above the measured number; the whole stated range lies above it.
By their numbers in this assay, from the lowest: compound 3; then compounds 2 and 1 (each within the scatter of the next).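

In this assay, among the compounds shown here, dimethylamino in place of pyrrolidin-1-yl on this aromatic carbon gives a number 0.96 log units lower from compound 2 to compound 3 (beyond the scatter) and is the only measured step at this position. The position is therefore not silent to this exchange, which removes the five-membered non-aromatic ring while the counts of hydrogen-bond donors and acceptors stay the same. No measurement available here accounts for the size of the step. Still open, as far as these compounds go, is how a piperidin-1-yl, morpholin-4-yl or diethylamino group would read at this position. Also open, from the compounds shown here alone, is whether the same exchange gives a similar step with other groups elsewhere on the shared core.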